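The source may report more compounds than this note shows. Statements on the series, on what has been measured and on what is new or still open speak of the compounds shown alone.

Measured in a functional assay on HT-29 cells (Homo sapiens); a lower number here means a stronger inhibitor, a higher number a weaker inhibitor:
- Compound 1 `NC(=O)c1nn([C@@H]2O[C@H](CO)[C@@H](O)[C@H]2O)cc1I`: > 300000 nM (a limit of the assay, not a number)
- Compound 2 `CCCCOC(=O)c1nn([C@@H]2O[C@H](CO)[C@@H](O)[C@H]2O)cc1I`: 25000 nM

Among the compounds with values here, compound 2, at 25000 nM, holds the only true number so far. The other result is the limit of > 300000 nM in this assay, at which 1 of the 2 values shown sits, and it belongs to compound 1.

The next compound is compound 3 `Cc1noc(-c2nn([C@@H]3O[C@H](CO)[C@@H](O)[C@H]3O)cc2I)n1`, not yet measured. It replaces the butoxycarbonyl of compound 2 with a 3-methyl-1,2,4-oxadiazol-5-yl group on an aromatic carbon: 3-methyl-1,2,4-oxadiazol-5-yl in place of butoxycarbonyl on an aromatic carbon. The shared core stays the same.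

Within the data shown here, only one measured step bears on this change, an at least 12-fold lower number from compound 1 to compound 2 (1.07 log units; beyond the scatter). That large step shows that this assay responds to what is attached at this carbon, but it changed only the group on the carbonyl. Compound 3 loses the carbonyl and the butyl chain altogether, so the step gives a weak guide to size and direction. A moderate move towards a higher number, meaning a weaker inhibitor, is expected, and a result at the limit remains possible.

The estimated change is a 2.4-fold higher number from compound 2 to compound 3 (0.38 log units; beyond the scatter). For compound 3 the expected value is 60000 nM, with an estimated range from 15000 nM to 250000 nM.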

Compound 3, half-maximal inhibitory concentration: 4800 nM
Compound 3: middle estimate off by 13-fold (1.10 log units), on the high side; measured number below the stated range.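

In this assay, activity at this carbon does not depend on a carbonyl or on a butyl chain, as the 3-methyl-1,2,4-oxadiazol-5-yl group has neither and still gives a 5.2-fold lower number from compound 2 to compound 3 (0.72 log units; beyond the scatter). Within the data shown here, the earlier compounds compared only two carbonyl groups, whereas this result shows that an aromatic ring with 3 hetero atoms can take the place of the carbonyl group here, and the change from the carbamoyl of the first compound gives an at least 62-fold lower number from compound 1 to compound 3 (1.79 log units; beyond the scatter). The size of that second step rests on compound 1, whose result is a limit of the assay and not a number: the limit of > 300000 nM in this assay, at which 1 of the 3 values shown sits.

From the compounds shown here alone, it remains open whether the ring itself or its methyl group accounts for the step, a question that a longer chain such as butyl on the same ring, or a phenyl ring in its place, could help to answer. The part played by the iodo group on the neighbouring ring atom is also open, as every compound shown carries it and none has a bromo group or a plain hydrogen there.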